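The source may report more compounds than this note shows. Statements on the series, on what has been measured and on what is new or still open speak of the compounds shown alone.

In an in vitro ADME assay on microsomes from liver (Homo sapiens) for metabolic stability (a lower number here means slower removal, a higher number faster removal of the compound), compound 1 (`O=C(COCc1ccccc1)N1CCN(c2cccc(Cl)c2)CC1`) gives 310 mL.min-1.g-1 and compound 2 (`O=C(COCc1ccccc1)N1CCN(c2ccc(F)cc2F)CC1`) gives 580 mL.min-1.g-1. These two numbers lie within the usual scatter of each other, so compound 2 cannot be told apart from compound 1. Among the compounds with values here, the only measured step is a 1.9-fold higher number from compound 1 to compound 2 (0.27 log units; within the scatter), with 2,4-difluorophenyl in place of 3-chlorophenyl.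

Compound 3 (`O=C(COCc1ccccc1)N1CCN(c2ccc(F)cc2Cl)CC1`) keeps the core of compound 2 and has chloro in place of fluoro on an aromatic carbon, ortho to a large group and meta to a fluoro group: chloro in place of fluoro on an aromatic carbon. Within the data shown here, the measured step is the only guide here. It also exchanges chloro and fluoro groups, though not at one matching place, and it stayed within the scatter. No step beyond the scatter is therefore expected in this assay. The estimated change is a 1.3-fold lower number from compound 2 to compound 3 (0.11 log units; within the scatter). For compound 3 the expected value is 450 mL.min-1.g-1, with an estimated range from 200 mL.min-1.g-1 to 900 mL.min-1.g-1.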

Compound 3, intrinsic clearance in microsomes: 530 mL.min-1.g-1
Estimate against measurement, compound 3: 1.2-fold (0.07 log units) below; measured number inside the range.
By their numbers in this assay, from the lowest: compounds 1, 3 and 2 (each within the scatter of the next).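

In this assay, the exchange of fluoro for chloro at the aromatic carbon ortho to a large group and meta to a fluoro group gives a 1.1-fold lower number from compound 2 to compound 3 (0.04 log units; within the scatter) and is the first step shown that changes this one place alone. Here, this single exchange leaves compound 2 and compound 3 indistinguishable, and the broader change to 2-chloro-4-fluorophenyl from 3-chlorophenyl gives a 1.7-fold higher number from compound 1 to compound 3 (0.23 log units; within the scatter) and also leaves its pair indistinguishable. No supporting data offer an explanation for these results.

Going by these compounds, whether a group other than chloro or fluoro at this place, such as methoxy, trifluoromethyl or an amine, would give a step beyond the scatter remains open. On these data alone, it is also open whether replacing the fluoro group at the other ring position would do so.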